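Bromo for Methyl on the Aryl Ring of a Thiocarbamate

The source may report more compounds than this note shows. Statements on the series, on what has been measured and on what is new or still open speak of the compounds shown alone.

Measured compounds:
- compound 1, `Cc1ccccc1NC(=S)OCCc1ccccn1`: > 100000 nM
- compound 2, `Cc1ccc(NC(=S)OCCc2ccccn2)cc1`: 75000 nM
- compound 3, `CCc1ccc(NC(=S)OCCc2ccccn2)cc1`: 44000 nM

Of the compounds shown here, three sharing a core have been tested in an ADME assay on MT4 cells (Homo sapiens) for cytotoxicity, read by MTT assay; on this read-out higher numbers stand for lower toxicity in this test and lower numbers for higher toxicity in this test. Compound 1 gives > 100000 nM, which is a limit of the assay and not a number. Compound 2 gives 75000 nM, and compound 3 gives 44000 nM. Among the two plain numbers, compound 2 holds the higher one, but the only measured step, a 1.7-fold lower number from compound 2 to compound 3 (0.23 log units; within the scatter), is within the scatter, so the two cannot be ordered.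

The new compound is compound 4, `S=C(Nc1ccc(Br)cc1)OCCc1ccccn1`. It differs from compound 2 in one place: bromo in place of methyl on an aromatic carbon. Within the data shown here, no measured step exchanges one aromatic substituent for another, so none bears directly on this change. Among the measured compounds shown here, the one step that exists, from a methyl added on a chain carbon, stayed within the scatter, and a change of a single heavy atom on the ring gives no reason to expect more. The step expected in this assay is therefore none beyond the scatter, as a 1.3-fold lower number from compound 2 to compound 4 (0.10 log units; within the scatter).

Compound 4 is estimated at 60000 nM, with a range from 25000 nM to 150000 nM.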

Compound 4, half-maximal cytotoxic concentration: 37000 nM
For compound 4 the middle estimate is 1.6-fold (0.21 log units) above the measured one; measured number inside the range.
By their numbers in this assay, from the lowest: compounds 4, 3 and 2 (each within the scatter of the next, the first and the last beyond it). At a limit, above all of these: compound 1.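

In this assay, among these compounds, putting bromo in place of methyl on the aromatic carbon para to a large group gives a 2.0-fold lower number from compound 2 to compound 4 (0.31 log units; beyond the scatter), the first step to leave the scatter, though only modestly. The lower number means higher toxicity in this test, so this position can shift the read-out when its group is exchanged, even though one heavy atom simply replaces another. Read against the ethyl compound, the same position gives a 1.2-fold lower number from compound 3 to compound 4 (0.08 log units; within the scatter), so bromo and ethyl cannot be told apart here, and nothing measured in this set explains the shift from methyl to bromo.

Going by these compounds, it remains open whether other groups at this position, such as chloro, an amine or a carboxylic acid, would move the number further, hold it in the same range or reverse the direction of the shift. On these data alone, compound 1 gives > 100000 nM, which is a limit of the assay and not a number, so how far it stands from the other compounds also remains open.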